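Sulfonyl substituent change in the pyrazoline series

This account rests on a few compounds, and the source may have more. Where it says the series, first, only, none or still open, it means among the compounds named here.

Compound 2 `CN(C)c1ccc(C2CC(c3ccc(-n4cncn4)cc3)=NN2S(C)(=O)=O)cc1` gives -3.1% in a functional assay on NCI-H1975 cells (Homo sapiens) for inhibition, read by sulforhodamine B assay, tested at 10 uM; on this read-out lower numbers stand for less inhibition and higher numbers for more inhibition at the one concentration tested (going by the name of the read-out); compound 1 `CN(C)c1ccc(C2CC(c3ccc(-n4cncn4)cc3)=NN2C(=O)CCCl)cc1` gives -0.7% there, the two numbers lying within the scatter. Among the measured compounds shown here, the only measured step, a number 2.4 percentage points lower from compound 1 to compound 2 (within the scatter), swaps the whole group on the ring nitrogen and moves nothing beyond the scatter. Compound 3 `CN(C)c1ccc(C2CC(c3ccc(-n4cncn4)cc3)=NN2S(=O)(=O)c2ccc(F)cc2)cc1` carries 4-fluorophenyl in place of methyl on a sulfonyl sulfur. For the measured compounds named here, no measured step touches the sulfonyl substituent itself, so the expectation rests on compound 2 at -3.1% and compound 1 at -0.7%, both near zero. For compound 3 the expected step is a number 6.1 percentage points higher from compound 2 to compound 3 (within the scatter), none beyond the scatter. Compound 3 is thus estimated at 3%, between -12% and 22%.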

Compound 3, a percentage reported as inhibition, at one concentration (the size of the read-out at that concentration, not a potency): -0.5%
Beside the measured number, compound 3's estimate is 3.5 percentage points above it; measured number inside the range.
By their numbers in this assay, from the lowest: compounds 2, 1 and 3 (each within the scatter of the next).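

In this assay, among the compounds shown here, an aromatic ring on the sulfonyl sulfur gives no step that can be read, with a number 2.6 percentage points higher from compound 2 to compound 3 (within the scatter). Set against the (2-chloroethyl)carbonyl group on the ring nitrogen, (4-fluorophenyl)sulfonyl also stays within the scatter, with a number 0.2 percentage points higher from compound 1 to compound 3 (within the scatter), so all three groups shown at this nitrogen remain indistinguishable. No evidence bears on this result. Open, from the compounds shown here alone, is whether an aminoalkyl chain on the sulfonyl sulfur or a carboxylic acid on the phenyl ring would give a step beyond the scatter. Also open, going by these compounds, is whether a morpholine in place of the dimethylamino group would do so.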